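The compounds below may be only part of what the source reports. "The series", "measured", "known", "first", "only" and "open" are said of these compounds alone.

The measured compounds:
Compound 1, `Oc1ccc(OC(=S)Nc2ccc(Nc3ccc(C(F)(F)F)cc3)cc2)cc1`, gives 9.23 in a physicochemical assay for acid dissociation.
Compound 2, `Oc1ccc(OC(=S)Nc2ccc(Sc3ccc(C(Cl)(Cl)Cl)cc3)cc2)cc1`, gives 9.22.
Compound 3, `Oc1ccc(OC(=S)Nc2ccc(Sc3ccc(C(F)(F)F)cc3)cc2)cc1`, gives 9.22.

Compound 4, `Oc1ccc(OC(=S)Nc2ccc(Nc3ccc(C(Cl)(Cl)Cl)cc3)cc2)cc1`, has not yet been measured. It arises from compound 1 by a single change: trichloromethyl in place of trifluoromethyl on an aromatic carbon Compound 2 and compound 3 show the same change, on the same kind of place: trichloromethyl in place of trifluoromethyl on an aromatic carbon Between those two measured compounds that change gave no change at the digits printed from compound 3 to compound 2 (within the scatter) The core of compound 1 and the core of compound 3 are not the same, but the difference between the two cores is not broken down here. The expectation for compound 4 therefore rests on compound 1 giving 9.23 and on the step of no change at the digits printed from compound 3 to compound 2 (within the scatter) The expected step is then no change at the digits printed from compound 1 to compound 4 (within the scatter), so in this assay compound 4 is estimated at 9.23, between 9.03 and 9.43.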

Compound 4, acid dissociation constant: 9.23
Estimate against measurement, compound 4: no gap at the digits printed; measured number inside the range.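

In this assay, putting trichloromethyl in place of trifluoromethyl gives no change at the digits printed from compound 1 to compound 4 (within the scatter), and the same change on a different core gives no change at the digits printed from compound 3 to compound 2 (within the scatter), so on these two cores the change has the same outcome. For the compounds shown here, these are only two pairs, so they show that the change carried over once, not that it will carry over to every core. Nothing shown here bears on why the number stays as it does.

The compounds shown leave open what a group other than these two, such as a nitrile or a carboxylic acid, would do in the same place on either core. On these data alone, whether the change would read the same outside this assay also stays open.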